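The source may report more compounds than this note shows. Statements on the series, on what has been measured and on what is new or still open speak of the compounds shown alone.

Among the compounds with values here, in an assay for inhibition of Polyunsaturated fatty acid 5-lipoxygenase (Rattus norvegicus) (a lower number here means a stronger inhibitor, a higher number a weaker inhibitor), compound 2 `CCCCC/C=C\C/C=C\C/C=C\C=C\C(N)CCCC(=O)O` gives 25000 nM, the highest of the two numbers measured so far; the nearest, compound 1 `CCCCC/C=C\C/C=C\C/C=C\C=C\C(CS)CCCC(=O)O`, gives 11000 nM. Within the data shown here, the only measured step, a 2.3-fold higher number from compound 1 to compound 2 (0.36 log units; beyond the scatter), describes the swap of sulfanylmethyl for amino. Compound 3 `CCCCC/C=C\C/C=C\C/C=C\C=C\C(CCCC(=O)O)OC(C)=O` is not yet measured; it differs from compound 2 by acetoxy in place of amino on a saturated chain carbon bound to a double-bonded chain carbon and a saturated chain carbon. Among the measured compounds shown here, no measured step involves an acetoxy group, so the single step is only a rough guide to size. Compound 3 is expected to give 20000 nM, between 7000 nM and 60000 nM. This estimate means an expected step of a 1.3-fold lower number from compound 2 to compound 3 (0.10 log units; within the scatter), within the scatter.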

Compound 3, half-maximal inhibitory concentration: 68000 nM
Compound 3: the middle estimate sits 3.4-fold (0.53 log units) below what was measured, outside the stated range (above it).
By their numbers in this assay, from the lowest: compound 1; then compound 2; then compound 3.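

In this assay acetoxy on this saturated chain carbon gives a 2.7-fold higher number from compound 2 to compound 3 (0.43 log units; beyond the scatter) and also a 6.2-fold higher number from compound 1 to compound 3 (0.79 log units; beyond the scatter) in the comparison with sulfanylmethyl. The position therefore tells these three groups apart, and compound 1, with sulfanylmethyl, is the strongest inhibitor of the three, while compound 3, with acetoxy, is the weakest. No measurement shown gives a reason for this order. Still open, as far as these compounds go, is how a hydroxyl group or a plain methyl group on this carbon would compare, and whether any group here could improve on sulfanylmethyl.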